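Swapping the oxadiazole for chlorophenyl: tolerance of cells

A few compounds are considered here, and "the series" means these few. Any claim that something is new, unique, unknown or untested is made for them only; others in the source may bear on it.

Compound 1, `O=C1N(CCC(CCOc2ccc(-c3ccc(Cl)cc3)cc2)Cc2ccccc2)CCN1c1ccncc1`, gives > 10000 nM in an ADME assay on cells (Homo sapiens) for cytotoxicity (a higher number here means that more compound is tolerated, a lower number that less compound is tolerated), which is a limit.
Compound 2, `CCc1nc(-c2ccc(OCCC(C)CCN3CCN(c4ccncc4)C3=O)cc2)no1`, gives > 25000 nM in this assay, again a limit.
Compound 3, `O=C1N(Cc2ccccc2COc2ccc(-c3ccc(Cl)cc3)cc2)CCN1c1ccncc1`, gives > 1250 nM in this assay, also a limit.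

Compound 2 therefore stands only at a limit of this assay, (the limit of > 25000 nM in this assay, at which 1 of the 3 values shown sits). Among the compounds with values here, the two other values shown are limits as well, so no compound here has a number, and no step between measured compounds can be drawn.

Compound 4, `CC(CCOc1ccc(-c2ccc(Cl)cc2)cc1)CCN1CCN(c2ccncc2)C1=O`, differs from compound 2 by 4-chlorophenyl in place of 5-ethyl-1,2,4-oxadiazol-3-yl on an aromatic carbon. Without a measured step for this change, the step of an at least 1.2-fold lower number from compound 2 to compound 4 (0.09 log units; that floor lies within the scatter) is expected to stay within the usual scatter. Compound 4 is thus expected at 20000 nM, in the range from 6000 nM to 50000 nM, and most likely it will again be reported only as a limit.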

Compound 4, half-maximal cytotoxic concentration: > 25000 nM
Compound 4 gave a limit, no number; the forecaster's own chance of this, stated with the estimate: 70%; middle value at least 1.2-fold (0.09 log units) away from the limit.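

Compound 4 again gave only a limit, so its steps from compound 1 and from compound 2 cannot be read. On these data alone, whether 4-chlorophenyl and 5-ethyl-1,2,4-oxadiazol-3-yl differ at all in this assay stays open.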